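The source may report more compounds than this note shows. Statements on the series, on what has been measured and on what is new or still open speak of the compounds shown alone.

Going by the values given here, compound 3 `CC(C)(C)c1ccc(C(=O)N2CCC3(CC2)C(=O)N(CC(=O)NCCCN)CN3c2ccccc2)cc1` is one of three compounds measured in an assay on HEK293 cells for displacement of a labelled ligand from NPC1-like intracellular cholesterol transporter 1 (Homo sapiens) (on this read-out lower numbers stand for stronger inhibition and higher numbers for weaker inhibition), where compound 3 gives 4200 nM. Among the compounds with values here, compound 1 `CC(C)(C)OC(=O)NCCCNC(=O)CN1CN(c2ccccc2)C2(CCN(C(=O)c3ccc(C4CCCCC4)cc3)CC2)C1=O` gives 6000 nM in this assay, a number within the scatter of the one for compound 3, so the two cannot be told apart. Compound 2 `CC1(C)CC(OC(=O)CN2CN(c3ccccc3)C3(CCN(C(=O)c4ccc(C5CCCCC5)cc4)CC3)C2=O)CC(C)(C)N1` gives 600 nM, and compound 3 thus stands second highest of the three, with compound 2 showing a clearly lower number. Within the data shown here, the only single-point step among the measured compounds runs between two of them: a 10-fold lower number from compound 1 to compound 2 (1.00 log units; beyond the scatter).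

Compound 4 `CC(C)(C)c1ccc(C(=O)N2CCC3(CC2)C(=O)N(CC(=O)NCCCCCO)CN3c2ccccc2)cc1` is not yet measured. It differs from compound 3 by 2-hydroxyethyl in place of amino on a saturated chain carbon, three bonds along the chain from an amide-type nitrogen. Among the measured compounds shown here, no measured step swaps an amino group for a 2-hydroxyethyl group, and the step from compound 1 to compound 2 involves a different pair of groups entirely. For the measured compounds named here, compound 1 and compound 3, for which no step is counted, show numbers within the scatter of one another. Taken together, the measured numbers give little reason to expect a shift beyond the scatter, so compound 4 is expected to give 5000 nM in this assay, within the range 1500 nM to 16000 nM. This amounts to an expected step of a 1.2-fold higher number from compound 3 to compound 4 (0.08 log units; within the scatter), most likely within the scatter.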

Compound 4, half-maximal inhibitory concentration: 9400 nM
For compound 4 the middle estimate is 1.9-fold (0.27 log units) below the measured one; the range from low to high includes it.
By their numbers in this assay, from the lowest: compound 2; then compounds 3, 1 and 4 (each within the scatter of the next, the first and the last beyond it).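

Going by these compounds alone, replacing the amino group with 2-hydroxyethyl on a saturated chain carbon, three bonds along the chain from an amide-type nitrogen, gives a 2.2-fold higher number from compound 3 to compound 4 (0.35 log units; beyond the scatter) in this assay and provides the first reading at this position, since the only earlier step concerned a carbonyl carbon. The step is modest but beyond the scatter, so this end of the chain does influence the number, and this particular change moves it towards weaker inhibition. The two groups have the same counts of hydrogen-bond donors and acceptors and the same net charge, so those counts do not separate them, and nothing available here explains the step.

The compounds shown leave open whether the end group or the chain length matters here: 3-aminopropyl gives way to 5-hydroxypentyl, so both change together. A 5-aminopentyl chain or a 3-hydroxypropyl chain would pull these two changes apart, and a carboxylic acid at the chain end would show how a different kind of end group behaves at this position.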